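This account rests on a few compounds, and the source may have more. Where it says the series, first, only, none or still open, it means among the compounds named here.

Working notes on the series. In an assay on microsomes from brain for inhibition of Fatty-acid amide hydrolase 1 (Rattus norvegicus), read by fluorescence and HPLC, with a stated time of 60 min (on this read-out lower numbers stand for stronger inhibition and higher numbers for weaker inhibition), compound 1 `CCCCCCCCc1ccc(OCC(=O)Cn2nnc(SC)n2)cc1` gives 31 nM. Compound 2 `CCCCCCCCc1ccc(OCC(=O)Cn2nnc(-c3cccc(Cl)c3)n2)cc1` gives 24 nM in this assay. Compound 3 `CCCCCCCCc1ccc(OCC(=O)Cn2nnnc2-c2ccc(Cl)cc2)cc1` gives 130 nM in this assay, the highest of the three numbers: the gap to compound 1 and the gap to compound 2 are both beyond the scatter, so compound 3 is the weakest inhibitor measured so far.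

Compound 4 `CCCCCCCCc1ccc(OCC(=O)Cn2nnnc2-c2ccccn2)cc1` differs from compound 3 in one place: pyridin-2-yl in place of 4-chlorophenyl on an aromatic carbon.

Among the measured compounds shown here, the one measured single-place step in this assay is a 1.3-fold lower number from compound 1 to compound 2 (0.11 log units; within the scatter), which puts 3-chlorophenyl in place of methylsulfanyl on an aromatic carbon and lies within the scatter. It does not exchange one six-membered aromatic ring for another and sits on a different attachment pattern from that of compound 3, so it bears on the present change only loosely. Compound 2 and compound 3 differ in more than one place, so only their two values can be set side by side. Lacking a closer precedent, no step beyond the scatter is expected, with the estimate held near the value of compound 3 and a wide range on either side. Compound 4 is therefore estimated at 150 nM, between 50 nM and 450 nM, an expected step of a 1.2-fold higher number from compound 3 to compound 4 (0.06 log units; within the scatter).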

Compound 4, half-maximal inhibitory concentration: 880 nM
For compound 4 the middle estimate is 5.9-fold (0.77 log units) below the measured one, outside the stated range (above it).
By their numbers in this assay, from the lowest: compounds 2 and 1 (each within the scatter of the next); then compound 3; then compound 4.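

Among the compounds shown here, on the aromatic carbon of the five-membered aromatic ring with 4 nitrogen, the choice of six-membered aromatic ring matters in this assay: pyridin-2-yl in place of 4-chlorophenyl gives a step beyond the scatter (a 6.8-fold higher number from compound 3 to compound 4 (0.83 log units; beyond the scatter)), whereas the one earlier single-place step (a 1.3-fold lower number from compound 1 to compound 2 (0.11 log units; within the scatter)) lay within it and on a different attachment pattern. The exchange removes the chlorine and places a nitrogen in the ring, taking the group from 0 hydrogen-bond acceptors to 1 hydrogen-bond acceptor, and these differences travel together in this single pair. Nothing measured on these compounds accounts for the rise in the number.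

The compounds shown leave open whether the rise goes with the ring nitrogen or with the loss of the chlorine: unsubstituted phenyl or pyridin-3-yl on this same carbon would begin to tell these apart. Also open, going by these compounds, is whether pyridin-2-yl in place of 3-chlorophenyl would give a step of similar size on the attachment pattern of compound 2.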